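A few compounds are considered here, and "the series" means these few. Any claim that something is new, unique, unknown or untested is made for them only; others in the source may bear on it.

Compound 1, whose structure is `Cc1nc(-c2ccc(OCC(C)C)c(C#N)c2)sc1C(=O)NCc1ccccc1`, has the lowest number of the three compounds measured in a physicochemical assay for lipophilicity (a higher number here means a more lipophilic compound, a lower number a more polar compound), giving 2.2. Its nearest neighbour is compound 2, `Cc1nc(-c2ccc(OCC(C)C)c(C#N)c2)sc1C(=O)NCc1ccccc1F`, which in this assay gives 2.9, a change of a number 0.70 log units higher from compound 1 to compound 2 (beyond the scatter). Furthest away is compound 3, `Cc1nc(-c2ccc(OCC(C)C)c(C#N)c2)sc1C(=O)Nc1ccccc1`, which in this assay gives 4.57, a change of a number 2.37 log units higher from compound 1 to compound 3 (beyond the scatter). The step from compound 2 to compound 3 is a number 1.67 log units higher from compound 2 to compound 3 (beyond the scatter).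

Compound 4, `COC(=O)c1sc(-c2ccc(OCC(C)C)c(C#N)c2)nc1C`, differs from compound 1 in one place: methoxy in place of benzylamino on a carbonyl carbon. Among the compounds with values here, none of the measured steps makes this exact change. The step from compound 1 to compound 3 shows that what sits on the amide-type nitrogen moves the number a great deal, and here the whole benzylamino group leaves and a much smaller methoxy group takes its place on the carbonyl carbon. The expectation is therefore a downward step beyond the scatter, estimated at a number 0.70 log units lower from compound 1 to compound 4 (beyond the scatter). Compound 4 is expected to give 1.5 in this assay, within a range of 0.8 to 2.4.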

Compound 4, partition coefficient: 1.63
Compound 4: middle estimate off by 0.13 log units, on the low side, within the range that was stated.
By their numbers in this assay, from the lowest: compound 4; then compound 1; then compound 2; then compound 3.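

Until now only the group on the amide-type nitrogen had changed, whereas here the whole group on the carbonyl carbon is exchanged, and methoxy gives a lower number in this assay against each of the other compounds: a number 0.57 log units lower from compound 1 to compound 4 (beyond the scatter), a number 1.27 log units lower from compound 2 to compound 4 (beyond the scatter) and a number 2.94 log units lower from compound 3 to compound 4 (beyond the scatter). The size of the step depends on which group leaves, with benzylamino giving the smallest drop, (2-fluorobenzyl)amino a larger one and anilino the largest. Compound 4 therefore has the lowest number of the four, with all three steps to it beyond the scatter.

The change removes a benzene ring and the amide hydrogen together, and no supporting evidence separates their contributions or explains the shift. Methylamino or ethoxy on the carbonyl carbon, or a carboxylic acid at this position, would show how far the number follows the size and type of the group there.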